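Imidazole for azetidinylamine on the benzylic carbon

The source may hold more compounds than are shown below. What is called first, only, known or untested is meant among the compounds shown, and "the series" means these compounds.

Measured compounds:
compound 1, `CCC[C@@H](CCO)Nc1nc(N)nc(C)c1Cc1ccc(CNC2CNC2)cc1OC`, > 10000 nM in an assay on HEK293 cells for agonist activity at Toll-like receptor 8 (Homo sapiens); a higher number here means that more compound is needed for the effect, a lower number that less compound is needed
compound 2, `CCC[C@@H](CO)Nc1nc(N)nc(C)c1Cc1ccc(CNC2CN(C)C2)cc1OC`, 6170 nM

The two measured compounds share the core and differ in more than one place, so their values can only be read side by side. Compound 1 sits at the limit of this assay, (the limit of > 10000 nM in this assay, at which 1 of the 2 values shown sits), and no number is known for it. Compound 2 gives 6170 nM, a number rather than a limit.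

Compound 3, `CCC[C@@H](CCO)Nc1nc(N)nc(C)c1Cc1ccc(Cn2ccnc2)cc1OC`, is compound 1 with one change: 1H-imidazol-1-yl in place of (azetidin-3-yl)amino on a saturated chain carbon bound to an aromatic carbon. Going by the values given here, no step between measured compounds matches that change, so nothing measured here tells its size or direction. Compound 1 already stands at the limit, and the expectation is that compound 3 remains weak, with the step that the limit leaves unreadable from compound 1 to compound 3 not going beyond the scatter. The estimate for compound 3 is 15000 nM, within 5000 nM to 50000 nM.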

Compound 3, half-maximal effective concentration: 4900 nM
Estimate against measurement, compound 3: 3.1-fold (0.49 log units) above; measured number outside the range, below it.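

In this assay compound 1 gives > 10000 nM, a limit of the assay and not a number. On the saturated chain carbon bound to an aromatic carbon, 1H-imidazol-1-yl in place of (azetidin-3-yl)amino gives an at least 2.0-fold lower number from compound 1 to compound 3 (0.30 log units; that floor lies within the scatter), and compound 3, at 4900 nM, shows that this position accepts a five-membered aromatic ring while still returning a measurable value. Only the floor of this step is known, so its true size stays unreadable: the limit of > 10000 nM in this assay, at which 1 of the 3 values shown sits.

From the compounds shown here alone, whether the value of compound 3 depends on the aromatic ring itself, or on its particular arrangement of ring nitrogens, remains open. A pyrazol-1-yl or a dimethylamino group on the same carbon would bear on that question.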